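A Smaller Ring on Compound 1

The compounds below may be only part of what the source reports. "The series", "measured", "known", "first", "only" and "open" are said of these compounds alone.

In a functional assay on PC-3 cells (Homo sapiens) for antiproliferative activity, read by sulforhodamine B assay (on this read-out lower numbers stand for stronger inhibition of growth and higher numbers for weaker inhibition of growth), compound 1 (`O=C(/C=C/c1ccc(O)cc1)c1c(O)cccc1OCCC1CCCCC1`) gives > 30000 nM, which is a limit of the assay and not a number. Compound 2 (`CC(C)(C)CCOc1cccc(O)c1C(=O)/C=C/c1ccc(S(N)(=O)=O)cc1`) gives a true number, 3250 nM. Compound 3 (`O=C(/C=C/c1ccc(O)cc1)c1c(O)cccc1OCCC1CCCC1`) carries cyclopentyl in place of cyclohexyl on a saturated chain carbon, two bonds along the chain from an oxygen on an aromatic ring. Going by the values given here, no measured step shows this change, so the expectation rests on compound 1 and its limit of > 30000 nM. In this assay, the expected step is small and stays within the scatter: a number no higher from compound 1 to compound 3 (the limit leaves the size open). The estimate for compound 3 is 30000 nM, with an expected range of 10000 nM to 60000 nM.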

Compound 3, concentration for 50% growth inhibition: 3480 nM
Compound 3: middle estimate off by 8.6-fold (0.94 log units), on the high side; the whole stated range lies above it.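

In this assay, the ring at this position turns out to matter: cyclopentyl in place of cyclohexyl gives an at least 8.6-fold lower number from compound 1 to compound 3 (0.93 log units; beyond the scatter). Removing a single ring carbon is thus enough to bring compound 3 to a measurable value on the same core. The true size of this step stays unknown, since compound 1 gives only a limit: the limit of > 30000 nM in this assay, at which 1 of the 3 values shown sits.

From the compounds shown here alone, whether a smaller ring such as cyclobutyl, or a nitrogen-containing ring such as piperidine, would be tolerated here remains open. So does whether the same swap would have a similar effect on another core.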